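A few compounds are considered here, and "the series" means these few. Any claim that something is new, unique, unknown or untested is made for them only; others in the source may bear on it.

In a functional assay on NCI-H1993 cells (Homo sapiens) for inhibition, read by CCK-8 assay, with a stated time of 72 h (a lower number here means a stronger inhibitor, a higher number a weaker inhibitor), compound 1 `CC(c1c(F)cc2ncccc2c1F)n1cnc2ncc(-c3cnn(CCO)c3)nc21` gives 83.7 nM. Compound 2 `Cc1c(C(C)n2cnc3ncc(-c4cnn(CCO)c4)nc32)ccc2ncccc12` gives 726 nM, the higher of the two numbers, with a gap beyond the scatter. Compound 3 `CCC(c1ccc2ncccc2c1F)n1cnc2ncc(-c3ccncc3)nc21` has no number, and its result stands as "not determined" (no result reported). Compound 4 `Cc1c(C(C)n2cnc3ncc(-c4cnc5ccccc5c4)nc32)ccc2ncccc12` is still to be measured in this assay. It differs from compound 2 in one place, with quinolin-3-yl in place of 1-(2-hydroxyethyl)-1H-pyrazol-4-yl on an aromatic carbon. Within the data shown here, no measured pair covers this exchange, so only a modest shift toward a weaker number is expected, close to the edge of the scatter. The expected change is a 1.5-fold higher number from compound 2 to compound 4 (0.18 log units; within the scatter). For compound 4 the estimated value is 1100 nM, with an expected range of 250 nM to 5000 nM.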

Compound 4, half-maximal inhibitory concentration: 450 nM
Beside the measured number, compound 4's estimate is 2.4-fold (0.39 log units) above it, within the range that was stated.
By their numbers in this assay, from the lowest: compound 1; then compounds 4 and 2 (each within the scatter of the next).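

In this assay, quinolin-3-yl replaces 1-(2-hydroxyethyl)-1H-pyrazol-4-yl on this aromatic carbon with a 1.6-fold lower number from compound 2 to compound 4 (0.21 log units; within the scatter), so the assay does not separate the two groups. Among these compounds, this position therefore accepts a two-ring aromatic group with no hydrogen-bond donors without a change beyond the scatter, which the earlier compounds, all differing in more than one place, could not show. Going by these compounds, whether an open-chain amine, a carboxylic acid or a morpholine ring at this position would move the number beyond the scatter remains open. Nothing available gives a reason for this result.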